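A few compounds are considered here, and "the series" means these few. Any claim that something is new, unique, unknown or untested is made for them only; others in the source may bear on it.

Compound 1: `COc1ccc(/C=C/C(=O)c2cccc(-n3cc(-c4ccccc4)nn3)c2)cc1O` — 1510 nM
Compound 2: `COc1ccc(/C=C/C(=O)c2cccc(-n3cc(-c4ccc(C)cc4)nn3)c2)cc1O` — 1700 nM

In a functional assay on RAW264.7 cells (Mus musculus) for inhibition, with a stated time of 4 days (a higher number here means a weaker inhibitor, a lower number a stronger inhibitor), compound 2 stands alongside compound 1; the step of a 1.1-fold higher number from compound 1 to compound 2 (0.05 log units; within the scatter) is within the scatter, so the two numbers are not distinguishable. Compound 3 `COc1ccc(-c2cn(-c3cccc(C(=O)/C=C/c4ccc(OC)c(O)c4)c3)nn2)cc1` differs from compound 2 by methoxy in place of methyl on an aromatic carbon. Going by the values given here, the only measured step that bears on this, a 1.1-fold higher number from compound 1 to compound 2 (0.05 log units; within the scatter), concerned a change at the same place and stayed within the scatter. Compound 3 is therefore expected to stay close to compound 2, with a step of no change at the digits printed from compound 2 to compound 3 (within the scatter) that is not beyond the scatter, because a 1.1-fold higher number from compound 1 to compound 2 (0.05 log units; within the scatter) gave no shift there. Compound 3 is estimated at 1700 nM, between 900 nM and 3200 nM.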

Compound 3, half-maximal inhibitory concentration: 6290 nM
Compound 3: the middle estimate sits 3.7-fold (0.57 log units) below what was measured; the measured number lies above the stated range.
By their numbers in this assay, from the lowest: compounds 1 and 2 (each within the scatter of the next); then compound 3.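

In this assay, this place on the six-membered aromatic ring of carbon only, para to a large group, proves not to be indifferent to what it carries: methoxy gives a 3.7-fold higher number from compound 2 to compound 3 (0.57 log units; beyond the scatter) and a 4.2-fold higher number from compound 1 to compound 3 (0.62 log units; beyond the scatter) as its two steps. The earlier swap of hydrogen for methyl had shown no such response, so among these three groups only methoxy moves the number beyond the scatter. Nothing at hand explains why methoxy parts from methyl here.

Going by these compounds, whether hydroxy, ethoxy or an amine at this place would follow methoxy or stay with methyl and hydrogen remains open. Also open, on these data alone, is whether the same change would behave alike on another core.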